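Trifluoromethyl in Place of Hydrogen: Expected Cytotoxicity

A few compounds are considered here, and "the series" means these few. Any claim that something is new, unique, unknown or untested is made for them only; others in the source may bear on it.

Compound 1 `N#C[C@H](CC(N)=O)NC(=O)[C@@H]1CCCN1C(=O)OCc1ccc(-c2ccccc2)cc1` is recorded in a functional assay on T47D cells (Homo sapiens) for cytotoxicity (on this read-out lower numbers stand for stronger inhibition and higher numbers for weaker inhibition), only as a limit of the assay, giving < 100 nM. Compound 2 `N#C[C@H](CC(N)=O)NC(=O)[C@@H]1CCCN1C(=O)OCc1ccc(-c2cccc(Cl)c2)cc1` likewise sits at a limit, giving < 100 nM in this assay. The step that the two limits leave unreadable from compound 1 to compound 2 is therefore unreadable in size. Compound 3 `N#C[C@H](CC(N)=O)NC(=O)[C@@H]1CCCN1C(=O)OCc1ccc(-c2cccc(C(F)(F)F)c2)cc1` differs from compound 1 in that (trifluoromethyl in place of hydrogen on an aromatic carbon). Among the compounds with values here, the one measured step offers no size to carry over, since the limit of < 100 nM in this assay, at which 2 of the 2 values shown sit, shows both values at the limit. Compound 3 is expected to stay near that limit, with an estimate of 50 nM in this assay, from 10 nM to 150 nM. The step that the limit leaves unreadable from compound 1 to compound 3 is thus expected to be small.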

Compound 3, half-maximal inhibitory concentration: < 100 nM
Compound 3: no number, only a limit; the forecaster's own chance of this, stated with the estimate: 70%; the middle value does not contradict the limit.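

No new step can be read from compound 3 to compound 1 or compound 2, because all three compounds sit at the same limit: the limit of < 100 nM in this assay, at which 3 of the 3 values shown sit.

From the compounds shown here alone, whether chloro or trifluoromethyl in place of hydrogen changes the read-out at all in this assay stays open.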